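This account rests on a few compounds, and the source may have more. Where it says the series, first, only, none or still open, it means among the compounds named here.

Working notes on the series.

Compound 1 `CCOC(=O)c1cnc(-c2ccncc2)nc1NN1C(=O)C=C(C)C1=O` gives 6000 nM in a functional assay on Jurkat cells for inhibition of nuclear factor NF-kappa-B complex (Homo sapiens); on this read-out higher numbers stand for weaker inhibition and lower numbers for stronger inhibition. Its two measured companions are compound 2 `CCOC(=O)c1cnc(-c2csc(C)n2)nc1NN1C(=O)C=C(C)C1=O` with 8000 nM and compound 3 `CCOC(=O)c1cnc(-n2nc(C)cc2C)nc1NN1C(=O)C=C(C)C1=O` with 10000 nM. Compound 1 holds the lowest of the three numbers, but neither of the other two stands clear of it: the step of a 1.3-fold higher number from compound 1 to compound 2 (0.12 log units; within the scatter) and the step of a 1.7-fold higher number from compound 1 to compound 3 (0.22 log units; within the scatter) both lie within the scatter, as does a 1.3-fold higher number from compound 2 to compound 3 (0.10 log units; within the scatter).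

The unmeasured compound 4 `CCOC(=O)c1cnc(-c2ccc(Cl)s2)nc1NN1C(=O)C=C(C)C1=O` differs from compound 1 in one place: 5-chlorothiophen-2-yl in place of pyridin-4-yl on an aromatic carbon. For the measured compounds named here, the steps that bear on this are the two exchanges of the same group at the same place in compound 1, namely a 1.3-fold higher number from compound 1 to compound 2 (0.12 log units; within the scatter) and a 1.7-fold higher number from compound 1 to compound 3 (0.22 log units; within the scatter). Both were within the scatter, so no step beyond the scatter is expected in this assay for this exchange either, in no particular direction. Compound 4 is therefore estimated at 7000 nM, with a range of 3000 nM to 16000 nM, which means an expected step of a 1.2-fold higher number from compound 1 to compound 4 (0.07 log units; within the scatter).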

Compound 4, half-maximal inhibitory concentration: 300 nM
For compound 4 the middle estimate is 23-fold (1.37 log units) above the measured one, outside the stated range (below it).
By their numbers in this assay, from the lowest: compound 4; then compounds 1, 2 and 3 (each within the scatter of the next).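

The position between two ring nitrogen atoms looked indifferent while it held pyridin-4-yl, 2-methyl-1,3-thiazol-4-yl or 3,5-dimethyl-1H-pyrazol-1-yl, but in this assay 5-chlorothiophen-2-yl brings a 20-fold lower number from compound 1 to compound 4 (1.30 log units; beyond the scatter), together with a 27-fold lower number from compound 2 to compound 4 (1.43 log units; beyond the scatter) and a 33-fold lower number from compound 3 to compound 4 (1.52 log units; beyond the scatter). A five-membered aromatic ring as such does not go with the low number, since compound 2 and compound 3 also carry one and stay within the scatter of compound 1. Nothing available explains this step.

As far as these compounds go, whether the step belongs to the chlorine or to the thiophene ring stays open, and unsubstituted thiophen-2-yl, 5-methylthiophen-2-yl or 4-chlorophenyl at this place would separate the two. Also open, from the compounds shown here alone, is whether the step survives when the ethoxycarbonyl group gives way to a carboxylic acid or an amide.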